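Widening the benzyl substituent on an EP4 antagonist series

A few compounds are considered here, and "the series" means these few. Any claim that something is new, unique, unknown or untested is made for them only; others in the source may bear on it.

Compound 2 `COc1cccc(Cc2sc3c(c2C(=O)N[C@@H](C)c2ccc(C(=O)O)cc2)CCOC3)c1` carries the lowest of the two numbers recorded in a functional assay on CHO/Galpha16 cells for antagonist activity at prostaglandin E2 receptor EP4 subtype (Homo sapiens), read by calcium flux, with a stated time of 15 min (a higher number here means a weaker inhibitor, a lower number a stronger inhibitor), where compound 2 gives 1.9 nM. Its nearest neighbour is compound 1 `COc1ccc(Cc2sc3c(c2C(=O)N[C@@H](C)c2ccc(C(=O)O)cc2)CCOC3)cc1`, which in this assay gives 2.1 nM; the step of a 1.1-fold lower number from compound 1 to compound 2 (0.04 log units; within the scatter) lies within the scatter, so the two are not distinguishable. Compound 3 `C[C@H](NC(=O)c1c(Cc2ccc(OC(F)(F)F)c(Cl)c2)sc2c1CCOC2)c1ccc(C(=O)O)cc1` differs from compound 2 by 3-chloro-4-(trifluoromethoxy)phenyl in place of 3-methoxyphenyl on a saturated chain carbon bound to an aromatic carbon. For the measured compounds named here, the only measured step that bears on this region, a 1.1-fold lower number from compound 1 to compound 2 (0.04 log units; within the scatter), shows that relocating the methoxy group on that ring left the number essentially unchanged, but no measured pair addresses exchanging the methoxy group for the larger, halogen-bearing group that enters here. Going by the values given here, with only that weak precedent, compound 3 is expected to stay close to compound 2 in this assay, with a step of a 1.3-fold higher number from compound 2 to compound 3 (0.12 log units; within the scatter) that may not exceed the scatter. Compound 3 is therefore estimated at 2.5 nM, within a range of 0.8 nM to 8 nM.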

Compound 3, half-maximal inhibitory concentration: 6.6 nM
The estimate for compound 3 lay 2.6-fold (0.42 log units) below the measured number; measured number inside the range.
By their numbers in this assay, from the lowest: compounds 2 and 1 (each within the scatter of the next); then compound 3.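

In this assay, for the compounds shown here, replacing a methoxyphenyl group on the saturated chain carbon produces the first change at this position that exceeds the scatter: a 3.5-fold higher number from compound 2 to compound 3 (0.54 log units; beyond the scatter) and a 3.1-fold higher number from compound 1 to compound 3 (0.50 log units; beyond the scatter). Moving the methoxy group had shown no distinguishable difference, whereas the larger 3-chloro-4-(trifluoromethoxy)phenyl group shows that the number at this position can respond to the substituents on the ring, though the rise is modest and compound 3 still reads 6.6 nM in this assay. Nothing measured here accounts for this rise.

From the compounds shown here alone, the chlorine and the trifluoromethoxy group enter together, so their separate contributions remain open, as does the reading of a 3-chlorophenyl or a 4-(trifluoromethoxy)phenyl group alone. Also open, going by these compounds, is how an amine or a hydroxyl group on that ring would read.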